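This account rests on a few compounds, and the source may have more. Where it says the series, first, only, none or still open, it means among the compounds named here.

Measured so far:
- compound 1, `OC[C@H]1O[C@@H](n2cnc3c(NCc4cccc(Br)c4)ncnc32)[C@H](O)[C@@H]1O`: 5000 nM
- compound 2, `COc1ccccc1CNc1ncnc2c1ncn2[C@@H]1O[C@H](CO)[C@@H](O)[C@H]1O`: 3200 nM
- compound 3, `OC[C@H]1O[C@@H](n2cnc3c(NCc4ccc(F)cc4Cl)ncnc32)[C@H](O)[C@@H]1O`: 20900 nM

All three were tested in a functional assay on CCRF-CEM cells (Homo sapiens) for antiproliferative activity, with a stated time of 72 h; a lower number here means a stronger inhibitor, a higher number a weaker inhibitor. Among them compound 3 has the highest number, so it is the weakest inhibitor of the three: the step of a 4.2-fold higher number from compound 1 to compound 3 (0.62 log units; beyond the scatter) and the step of a 6.5-fold higher number from compound 2 to compound 3 (0.81 log units; beyond the scatter) both lie beyond the scatter, while compound 1 and compound 2 sit within the scatter of each other, as shown by a 1.6-fold lower number from compound 1 to compound 2 (0.19 log units; within the scatter).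

Compound 4, `COc1cccc(CNc2ncnc3c2ncn3[C@@H]2O[C@H](CO)[C@@H](O)[C@H]2O)c1O`, has not yet been measured. It differs from compound 3 in one place: 2-hydroxy-3-methoxyphenyl in place of 2-chloro-4-fluorophenyl on a saturated chain carbon bound to a nitrogen on an aromatic ring. For the measured compounds named here, the aryl group that enters carries a methoxy group, as does compound 2, plus a hydroxyl; no measured compound carries the hydroxyl. The step of a 6.5-fold higher number from compound 2 to compound 3 (0.81 log units; beyond the scatter) is the most relevant guide, and reversing that kind of change points to a lower number. A modest drop in this assay is therefore expected, roughly a 4.2-fold lower number from compound 3 to compound 4 (0.62 log units; beyond the scatter). Compound 4 is estimated at 5000 nM, with a plausible range from 1500 nM to 16000 nM.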

Compound 4, half-maximal inhibitory concentration: 300 nM
Compound 4: the middle estimate sits 17-fold (1.22 log units) above what was measured; measured number outside the range, below it.
By their numbers in this assay, from the lowest: compound 4; then compounds 2 and 1 (each within the scatter of the next); then compound 3.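

In this assay, for the compounds shown here, the aryl group on this saturated chain carbon bound to a nitrogen on an aromatic ring matters far more than the earlier compounds showed, and a 70-fold lower number from compound 3 to compound 4 (1.84 log units; beyond the scatter) is the largest step seen so far. Compound 4 also stands clear of the other two, with a 17-fold lower number from compound 1 to compound 4 (1.22 log units; beyond the scatter) and an 11-fold lower number from compound 2 to compound 4 (1.03 log units; beyond the scatter) in a step where both aryl groups carry a methoxy group and only the entering one carries a hydroxyl. A methoxy group alone therefore does not reach this level, and compound 4, the only one with a hydroxyl on the aryl group, is the strongest inhibitor of the four.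

As far as these compounds go, whether the hydroxyl alone accounts for the gain stays open, as does whether an amine or a carboxylic acid in its place would keep it. Nothing available explains the size of this jump.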